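Replacing 3-aminophenyl with 4-methylphenyl on a shared core

This account rests on a few compounds, and the source may have more. Where it says the series, first, only, none or still open, it means among the compounds named here.

In a functional assay on A549 cells (Homo sapiens) for antiproliferative activity, read by MTT assay, with a stated time of 72 h (on this read-out higher numbers stand for weaker inhibition and lower numbers for stronger inhibition), three compounds sharing one core have been measured. Compound 3 `COc1cc(-n2cnc3ccc(-c4cccc(N)c4)cc32)cc(OC)c1OC` gives 640 nM and holds the lowest number of the three, which here means the strongest inhibition. Compound 1 `COc1ccc(-c2ccc3ncn(-c4cc(OC)c(OC)c(OC)c4)c3c2)cc1F` gives 1430 nM and compound 2 `COc1cc(-n2cnc3ccc(-c4ccc(C(F)(F)F)cc4)cc32)cc(OC)c1OC` gives 3390 nM as the highest number of the set.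

Compound 4 `COc1cc(-n2cnc3ccc(-c4ccc(C)cc4)cc32)cc(OC)c1OC` has not yet been measured. It carries 4-methylphenyl in place of 3-aminophenyl on an aromatic carbon, a swap summed up as 4-methylphenyl in place of 3-aminophenyl on an aromatic carbon with the core left unchanged. The measured compounds differ at this same place, so their steps are the best guide available. The two groups other than 3-aminophenyl also differ from each other, with a 2.4-fold higher number from compound 1 to compound 2 (0.37 log units; beyond the scatter) as the gap between them.

Compound 4 gives up 3-aminophenyl, so the two steps of a 2.2-fold lower number from compound 1 to compound 3 (0.35 log units; beyond the scatter) and a 5.3-fold lower number from compound 2 to compound 3 (0.72 log units; beyond the scatter), read backwards, point to a modestly higher number in this assay for it. Going by the values given here, no measured compound carries 4-methylphenyl, so the size remains uncertain. The estimated change is a 2.3-fold higher number from compound 3 to compound 4 (0.37 log units; beyond the scatter) in this expectation. Compound 4 is expected to give 1500 nM with 600 nM to 3800 nM as the estimated range.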

Compound 4, half-maximal inhibitory concentration: 1940 nM
Estimate against measurement, compound 4: 1.3-fold (0.11 log units) below; low and high end bracket the measured number.
By their numbers in this assay, from the lowest: compound 3; then compounds 1, 4 and 2 (each within the scatter of the next, the first and the last beyond it).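

In this assay, 4-methylphenyl gives a 3.0-fold higher number from compound 3 to compound 4 (0.48 log units; beyond the scatter) and so compound 3, with its 3-aminophenyl, now stands apart from all three other compounds by steps beyond the scatter, which makes it the strongest inhibitor of the four. Compound 4 also links the two earlier compounds that were separated beyond the scatter: the steps of a 1.4-fold higher number from compound 1 to compound 4 (0.13 log units; within the scatter) and a 1.7-fold lower number from compound 2 to compound 4 (0.24 log units; within the scatter) both stay within the scatter, so it cannot be ranked against either one. The second of these steps is the only one here that alters just the group on the phenyl ring, methyl in place of trifluoromethyl, and on its own it does not separate the two compounds.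

No available measurement explains why compound 3 stands apart. As far as these compounds go, the names 3-aminophenyl and 4-methylphenyl differ both in the group carried and in the place it holds on the ring, so the data cannot separate these two changes, and it remains open how a phenyl ring carrying a hydroxyl, an amide or a dimethylamine would compare with compound 3.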